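Cyclohexyl on the carbonyl carbon: compound 3 to compound 4

This account rests on a few compounds, and the source may have more. Where it says the series, first, only, none or still open, it means among the compounds named here.

Values so far in an ADME assay on Vero cells (Chlorocebus sabaeus) for cytotoxicity, read by MTT assay, with a stated time of 48 h; on this read-out higher numbers stand for weaker inhibition and lower numbers for stronger inhibition (each one a limit)
- compound 1 (`CS(=O)(=O)OC1CCC(CN2CCN(c3cc(=O)c4cc(C(F)(F)F)cc([N+](=O)[O-])c4s3)CC2)CC1`) gives (> 64 ug/mL)
- compound 2 (`C=CC(=O)OC1CCC(CN2CCN(c3cc(=O)c4cc(C(F)(F)F)cc([N+](=O)[O-])c4s3)CC2)CC1`) gives (> 64 ug/mL)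
- compound 3 (`O=C(OC1CCC(CN2CCN(c3cc(=O)c4cc(C(F)(F)F)cc([N+](=O)[O-])c4s3)CC2)CC1)c1ccc2c(c1)OCC2`) gives (> 64 ug/mL)

Compound 3 stands only at a limit (> 64 ug/mL) and has no number. Within the data shown here, the series as a whole sits at one value (the limit of > 64 ug/mL in this assay, at which 3 of the 3 values shown sit) in this assay so far. Compound 4 (`O=C(OC1CCC(CN2CCN(c3cc(=O)c4cc(C(F)(F)F)cc([N+](=O)[O-])c4s3)CC2)CC1)C1CCCCC1`) differs from compound 3 on the carbonyl carbon (a group of 6 heavy atoms (6 carbon; one six-membered non-aromatic ring of carbon only) in place of a group of 9 heavy atoms (8 carbon, 1 oxygen; one five-membered non-aromatic ring with 1 hetero atom, one six-membered aromatic ring of carbon only), on a carbonyl carbon) and carries cyclohexyl there. The closest measured change is (a step that the two limits leave unreadable from compound 2 to compound 3) and two others sit with it (a step that the two limits leave unreadable from compound 1 to compound 2) (a step that the two limits leave unreadable from compound 1 to compound 3), so none gives a size to carry over. No step beyond the scatter is expected (a step that the limit leaves unreadable from compound 3 to compound 4) in either direction. For compound 4 the estimated value is (80 ug/mL) with an expected range from (45 ug/mL) to (128 ug/mL) and a report as a limit is the likeliest outcome.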

Compound 4, half-maximal inhibitory concentration: > 64 ug/mL
Compound 4: no number, only a limit; the forecaster's own chance of this, stated with the estimate: 85%; the middle value lies beyond the limit too.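

In this assay, among these compounds, compound 4 gives only the limit > 64 ug/mL and no number, so no step from compound 1, compound 2 or compound 3 to compound 4 can be read. Whether any group on the carbonyl carbon gives a measurable value stays open: the limit of > 64 ug/mL in this assay, at which 4 of the 4 values shown sit.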